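The source may hold more compounds than are shown below. What is called first, only, known or untested is meant among the compounds shown, and "the series" means these compounds.

Measured in a functional assay on A549 cells (Homo sapiens) for cytotoxicity, read by MTT assay; a higher number here means a weaker inhibitor, a lower number a stronger inhibitor:
Compound 1 `COc1ccc(-c2oc3c(CC=C(C)C)c(OCCCC(=O)O)cc(O)c3c(=O)c2O)cc1`: 19100 nM
Compound 2 `COc1ccc(-c2oc3c(CC=C(C)C)c(OCC(=O)O)cc(O)c3c(=O)c2O)cc1`: 16700 nM

For the measured compounds named here, these two values lie within the scatter of each other, so compound 1 stands level with the only other measured compound. Compound 3 `COc1ccc(-c2oc3c(CC=C(C)C)c(OCCCC(=O)O)cc(O)c3c(=O)c2OCCCC(=O)O)cc1` keeps the whole of compound 1 and adds one change: 3-carboxypropyl in place of hydrogen on an oxygen on an aromatic ring, or hydroxy to 3-carboxypropoxy. Going by the values given here, the single measured step, a 1.1-fold lower number from compound 1 to compound 2 (0.06 log units; within the scatter), lies within the scatter, but it alters a chain already present on another oxygen and so bears on this change only loosely. Among the compounds with values here, no measured step replaces this hydroxy, so the expectation remains uncertain. On that slim evidence, no step beyond the scatter is expected in this assay. The expected step, a 1.2-fold higher number from compound 1 to compound 3 (0.06 log units; within the scatter), is small. For compound 3 the estimate is 22000 nM, with an expected range of 9000 nM to 60000 nM.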

Compound 3, half-maximal inhibitory concentration: 26000 nM
Beside the measured number, compound 3's estimate is 1.2-fold (0.07 log units) below it; the range from low to high includes it.
By their numbers in this assay, from the lowest: compounds 2, 1 and 3 (each within the scatter of the next).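

In this assay, for the compounds shown here, this is the first look at the hydroxy oxygen on the aromatic ring that the earlier compounds left unsubstituted, since their only difference lay in the chain on another oxygen. Putting 3-carboxypropyl on this oxygen gives a 1.4-fold higher number from compound 1 to compound 3 (0.13 log units; within the scatter) and so leaves the read-out level, even though compound 3 carries this chain on two oxygens of the shared core. Nothing available explains why the number holds level at this oxygen.

On these data alone, whether a shorter chain such as carboxymethyl would also stay level here remains open, as does the effect of an amine or a methyl ester at the end of the chain. As far as these compounds go, it is also open whether any group on this oxygen could move the number beyond the scatter.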